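Swapping a Dimethylamino Group for a Chlorobenzylamino Group

This account rests on a few compounds, and the source may have more. Where it says the series, first, only, none or still open, it means among the compounds named here.

Compound 1 `COc1cc(/C=C/c2nccc(NC(C)C)n2)cc(OC)c1OC`: < 40000 nM
Compound 2 `Brc1cccc(Nc2nc(/C=C/c3ccccc3)nc3ccsc23)c1`: > 1000000 nM
Compound 3 `COc1cc(/C=C/c2nc(N(C)C)c3sccc3n2)cc(OC)c1OC`: > 1000000 nM

All three measurements come from a functional assay on L02 cells (Homo sapiens) for inhibition, read by Griess assay, with stated times of 1 h and 24 h; a higher number here means a weaker inhibitor, a lower number a stronger inhibitor. Compound 1 reaches only a limit of the assay, < 40000 nM, and not a number. Compound 2 also stops at a limit, > 1000000 nM. Within the data shown here, compound 3 stands at the same kind of limit, > 1000000 nM, so for compound 3 nothing is known beyond the fact that its potency is weak enough to fall outside what the assay reports; two of the three results sit there, as the limit of > 1000000 nM in this assay, at which 2 of the 3 values shown sit, shows, while the limit of < 40000 nM in this assay, at which 1 of the 3 values shown sits, is the only value pointing toward measurable inhibition.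

Compound 4 `COc1cc(/C=C/c2nc(NCc3ccc(Cl)cc3)c3sccc3n2)cc(OC)c1OC` has not yet been measured. It keeps the core of compound 3 and changes one place: (4-chlorobenzyl)amino in place of dimethylamino on an aromatic carbon. Among the measured compounds shown here, no measured pair in this set isolates such a change, so its effect can only be guessed.

Given that compound 3 sits at a limit with > 1000000 nM, the step is expected to move toward stronger inhibition, by about an at least 3.3-fold lower number from compound 3 to compound 4 (0.52 log units; beyond the scatter). Compound 4 is therefore expected to give roughly 300000 nM, within a range from 30000 nM to 2000000 nM, with a real chance that the assay again reports only a limit.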

Compound 4, half-maximal inhibitory concentration: > 1000000 nM
Compound 4: a limit, no number; the forecaster's own chance of this, stated with the estimate: 55%; at least 3.3-fold (0.52 log units) between middle value and limit.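

Among these compounds, compound 3 and compound 4 both stop at a limit of this assay and not at a number, so swapping dimethylamino for (4-chlorobenzyl)amino gives no step that can be read. The compounds shown leave open how large this change's effect on inhibition is, and even in which direction it goes.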